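The source may hold more compounds than are shown below. What is called first, only, known or untested is meant among the compounds shown, and "the series" means these compounds.

Compounds measured so far:
- compound 1 `CC1(C)N=C(N)N=C(N)N1c1ccc(CCC(=O)Nc2ccc(S(=O)(=O)F)cc2)cc1`, which in an assay on isolated protein for inhibition of Dihydrofolate reductase (Mus musculus) (a higher number here means a more potent compound, by a factor of ten per unit of this negative logarithm, a lower number a less potent compound), gives 7.6
- compound 2 `CC1(C)N=C(N)N=C(N)N1c1ccc(CC(C(=O)Nc2cccc(S(=O)(=O)F)c2)c2ccccc2)cc1`, which in this assay gives 6.89

Compound 2 stands at the lower of the two numbers; compound 1 lies higher by a margin beyond the usual scatter. Compound 3 `CC1(C)N=C(N)N=C(N)N1c1ccc(CCC(=O)Nc2cccc(S(=O)(=O)F)c2)cc1` has not yet been measured. It differs from compound 2 by hydrogen in place of phenyl on a saturated chain carbon bound to a carbonyl carbon and a saturated chain carbon. With the phenyl gone, compound 3 carries the same saturated chain to the carbonyl as compound 1, and compound 1 gives 7.6, whereas compound 2 gives 6.89. Going by the values given here, no step between measured compounds is available to fix the size of this change. The expectation is that removing the phenyl lifts potency, with a step from compound 2 to compound 3 of about a number 0.51 log units higher from compound 2 to compound 3 (beyond the scatter) expected. Compound 3 is accordingly estimated at 7.4, with a range from 6.9 to 7.9.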

Compound 3, logarithm of the reciprocal of the active concentration, log(1/C): 7.74
Estimate against measurement, compound 3: 0.34 log units below, and the stated range covers the measured number.
By their numbers in this assay, from the lowest: compound 2; then compounds 1 and 3 (each within the scatter of the next).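

In this assay, hydrogen in place of phenyl on the saturated chain carbon gives a number 0.85 log units higher from compound 2 to compound 3 (beyond the scatter), the first direct measure of what this phenyl costs when nothing else in the structure changes. With that chain free of phenyl, 3-(fluorosulfonyl)phenyl in place of 4-(fluorosulfonyl)phenyl on the amide-type nitrogen gives a number 0.14 log units higher from compound 1 to compound 3 (within the scatter), so these two placings of the fluorosulfonyl group cannot be told apart on this chain. Nothing in hand accounts for either step.

The compounds shown leave open whether a group smaller than phenyl on that carbon, such as methyl or an amine, would also give a lower number. They also leave open whether phenyl at this place would give a step of similar size with 4-(fluorosulfonyl)phenyl on the amide-type nitrogen.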